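A fluorophenyl swap at the cytotoxicity limit

A few compounds are considered here, and "the series" means these few. Any claim that something is new, unique, unknown or untested is made for them only; others in the source may bear on it.

In a functional assay on HEK293 cells (Homo sapiens) for cytotoxicity (on this read-out higher numbers stand for lower toxicity in this test and lower numbers for higher toxicity in this test), compound 3 (`COc1ccc([C@H]2CC(=O)N(c3cccc(NS(=O)(=O)c4cccc(Cl)c4C)c3)C2)cc1OC1CCCC1`) gives > 10000 nM as a limit of the assay, not as a number. Compound 1 (`COc1ccc([C@H]2CC(=O)N(c3cccc(C)c3)C2)cc1OC1CCCC1`) likewise gives > 10000 nM as a limit. Compound 2 (`COc1ccc(OC)c(S(=O)(=O)Nc2cccc(N3C[C@@H](c4ccc(OC)c(OC5CCCC5)c4)CC3=O)c2)c1`) gives 7590 nM as a true number. Compound 3 therefore stands at the limit (the limit of > 10000 nM in this assay, at which 2 of the 3 values shown sit), so its exact place is not known.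

Compound 4 (`COc1ccc([C@H]2CC(=O)N(c3cccc(NS(=O)(=O)c4cccc(F)c4)c3)C2)cc1OC1CCCC1`) carries 3-fluorophenyl in place of 3-chloro-2-methylphenyl on a sulfonyl sulfur. Among the compounds with values here, only two measured steps bear on this change. Within the data shown here, the one exchange of the group on the sulfonyl sulfur shows an at least 1.3-fold higher number from compound 2 to compound 3 (0.11 log units; that floor lies within the scatter) as its measured size, and that is the closest guide available. The other measured step is a step that the two limits leave unreadable from compound 1 to compound 3 and adds no usable size.

On this evidence, no change beyond the scatter is expected in this assay for the new group, and no direction can be named. The expected step is a number no higher from compound 3 to compound 4 (the limit leaves the size open) on this reading, with the limit making its size uncertain. Compound 4 is estimated at 10000 nM with an expected range from 6000 nM to 20000 nM, and a limit of the assay is a likely outcome for it.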

Compound 4, half-maximal cytotoxic concentration: > 10000 nM
Compound 4: only a limit was reported; the forecaster's own chance of this, stated with the estimate: 70%; the middle value sits exactly at the limit.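

In this assay compound 4 gives > 10000 nM, which is a limit of the assay and not a number. Within the data shown here, the exchange on the sulfonyl sulfur therefore shows that 3-fluorophenyl, like 3-chloro-2-methylphenyl, can occupy this place with the read-out still at the limit, and the one readable step, an at least 1.3-fold higher number from compound 2 to compound 4 (0.11 log units; that floor lies within the scatter), has a floor that does not go beyond the scatter. The other two steps to compound 4 cannot be read, and the series now sits largely at one value: the limit of > 10000 nM in this assay, at which 3 of the 4 values shown sit.

The compounds shown do not reveal how compound 1, compound 3 and compound 4 truly rank against one another, nor whether any exchange on the sulfonyl sulfur gives a change beyond the scatter, since compound 2 alone carries a true number, 7590 nM. Also open, as far as these compounds go, is how this read-out would respond to an amine, a carboxylic acid or a longer alkyl chain on the sulfonyl sulfur in place of these aromatic groups.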